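A Bromobenzyl Amine Replaces a Small Dimethylamine

The compounds below may be only part of what the source reports. "The series", "measured", "known", "first", "only" and "open" are said of these compounds alone.

Of the compounds shown here, two with a shared core have been measured so far. Compound 1, `CCN1CCN(Cc2c(OC)cc(Oc3cccc(Nc4ccccc4)c3)cc2OC)CC1`, carries a 4-ethylpiperazin-1-yl group on a saturated chain carbon bound to an aromatic carbon. In a functional assay on DLD-1 cells (Homo sapiens) for inhibition, read by MTT assay, with a stated time of 72 h (on this read-out lower numbers stand for stronger inhibition and higher numbers for weaker inhibition), compound 1 gives > 20000 nM, which is a limit of the assay rather than a number. Compound 2, `COc1cc(Oc2cccc(Nc3ccccc3)c2)cc(OC)c1CN(C)C`, carries a dimethylamino group at the same place. In this assay compound 2 gives > 20000 nM, again a limit and not a number. The step between them is a step that the two limits leave unreadable from compound 1 to compound 2. Both results sit at the limit of > 20000 nM in this assay, at which 2 of the 2 values shown sit, so compound 2 stands at the edge of what this assay reports, without a number of its own.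

Compound 3, `COc1cc(Oc2cccc(Nc3ccccc3)c2)cc(OC)c1CNCc1ccc(Br)cc1`, differs from compound 2 by (4-bromobenzyl)amino in place of dimethylamino on a saturated chain carbon bound to an aromatic carbon. Within the data shown here, the one measured step, a step that the two limits leave unreadable from compound 1 to compound 2, cannot be read, so no measured step tells how far a change at this position moves the read-out, in either direction. The estimate for compound 3 in this assay is therefore expected to lie near 15000 nM, within a wide range from 3000 nM to 50000 nM. This expected value corresponds to a step of an at least 1.3-fold lower number from compound 2 to compound 3 (0.12 log units; that floor lies within the scatter), with a real chance that only a limit is again reported.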

Compound 3, half-maximal inhibitory concentration: 3520 nM
For compound 3 the middle estimate is 4.3-fold (0.63 log units) above the measured one; low and high end bracket the measured number.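

Among these compounds, compound 3 is the first compound here to give a real number in this assay, which shows that a change at this saturated chain carbon bound to an aromatic carbon can move the read-out by a measurable amount. Putting (4-bromobenzyl)amino in place of dimethylamino gives an at least 5.6-fold lower number from compound 2 to compound 3 (0.75 log units; beyond the scatter), and putting it in place of 4-ethylpiperazin-1-yl gives an at least 5.6-fold lower number from compound 1 to compound 3 (0.75 log units; beyond the scatter). Both steps are floors rather than exact sizes, because the two starting compounds report only a limit of the assay: the limit of > 20000 nM in this assay, at which 2 of the 3 values shown sit.

The step between compound 1 and compound 2 still cannot be read, so nothing shown separates the dimethylamino and 4-ethylpiperazin-1-yl groups from each other. The entering group also differs from both in several ways at once, bringing an aromatic ring, a bromine and a hydrogen-bond donor, so a plain benzylamino group without the bromine, or an N-methyl-N-(4-bromobenzyl)amino group without that donor, would be needed to tell which of these parts goes with the lower number.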